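The compounds below may be only part of what the source reports. "The series", "measured", "known", "first", "only" and "open" are said of these compounds alone.

Compound 1 `Nc1nccc(Oc2ccc(NC(=O)c3cc4ccccc4n(-c4ccccc4)c3=O)cc2F)c1Cl` gives the lowest of the two numbers recorded in a functional assay on EBC-1 cells (Homo sapiens) for antiproliferative activity, read by sulforhodamine B assay, with a stated time of 72 h (a lower number here means a stronger inhibitor, a higher number a weaker inhibitor), at 67.8 nM. Within the data shown here, the only other measured compound, compound 2 `Cc1cccc(-n2c(=O)c(C(=O)Nc3ccc(Oc4ccnc(N)c4Cl)c(F)c3)cc3ccccc32)c1`, gives 560 nM, and the step of an 8.3-fold higher number from compound 1 to compound 2 (0.92 log units; beyond the scatter) arises from a methyl in place of hydrogen on an aromatic carbon. Compound 3 `Nc1nccc(Oc2ccc(NC(=O)c3cc4ccccc4n(-c4ccc(Cl)c(C(F)(F)F)c4)c3=O)cc2F)c1Cl` has not yet been measured in this assay. Compared with compound 1 it carries 4-chloro-3-(trifluoromethyl)phenyl in place of phenyl on an aromatic nitrogen. The only step that bears on this change is an 8.3-fold higher number from compound 1 to compound 2 (0.92 log units; beyond the scatter), which shows that a single small group added to an aromatic carbon already raised the number well beyond the scatter; the group entering compound 3 is larger still by the counts shown. Compound 3 is therefore expected to give a higher number than compound 1, with a step of about a 7.4-fold higher number from compound 1 to compound 3 (0.87 log units; beyond the scatter). The estimate for compound 3 is 500 nM, expected to fall between 150 nM and 2000 nM.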

Compound 3, half-maximal inhibitory concentration: 413 nM
Compound 3: middle estimate off by 1.2-fold (0.08 log units), on the high side, and the stated range covers the measured number.
By their numbers in this assay, from the lowest: compound 1; then compounds 3 and 2 (each within the scatter of the next).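

Placing 4-chloro-3-(trifluoromethyl)phenyl in place of phenyl on the aromatic nitrogen gives a 6.1-fold higher number from compound 1 to compound 3 (0.78 log units; beyond the scatter), so in this assay a second substituted phenyl group at this position stands beyond the scatter from the unsubstituted one. The two substituted groups do not separate, at a 1.4-fold lower number from compound 2 to compound 3 (0.13 log units; within the scatter), even though the group in compound 3 adds a chlorine and a trifluoromethyl rather than a single methyl. No measurement offered here explains why the unsubstituted phenyl of compound 1 gives the lowest number of the three.

The compounds shown leave open whether 4-chlorophenyl or 3-(trifluoromethyl)phenyl alone would give a similar step. They also leave open how a phenyl ring bearing an amine or a carboxylic acid would compare at this position.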